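From nitro to dimethylamino: compound 1 and compound 3

This account rests on a few compounds, and the source may have more. Where it says the series, first, only, none or still open, it means among the compounds named here.

The starting point is compound 1 (`Cc1cc(NC(=O)Nc2cccc([N+](=O)[O-])c2)c2ccccc2n1`), tested in an ADME assay on HepG2 cells (Homo sapiens) for cytotoxicity, with a stated time of 72 h; a higher number here means that more compound is needed for the effect, a lower number that less compound is needed. In this assay compound 1 gives > 25000 nM, and this is a limit of the assay, not a number. Among the measured compounds shown here, the only other compound measured so far is compound 2 (`Cc1cc(NC(=O)Nc2ccc(SC(F)(F)F)cc2)c2ccccc2n1`), which gives a true number: in this assay compound 2 reads 20000 nM.

Compound 3 (`Cc1cc(NC(=O)Nc2cccc(N(C)C)c2)c2ccccc2n1`) has not yet been measured. It keeps the core of compound 1 but carries dimethylamino in place of nitro on an aromatic carbon, meta to a large group (dimethylamino in place of nitro on an aromatic carbon). For the measured compounds named here, no measured pair shows what a single change of this kind does in this assay, so any forecast is loose. Going by the values given here, the one number available is compound 2 at 20000 nM, and it gives no reason to expect a large drop. The expected change, an at least 1.1-fold lower number from compound 1 to compound 3 (0.05 log units; that floor lies within the scatter), is small, if anything toward less compound needed, and it may not go beyond the usual scatter. Compound 3 could also end up reported only as a limit. For compound 3 the estimated value is 22000 nM, with an expected range from 9000 nM to 35000 nM.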

Compound 3, half-maximal effective concentration: > 25000 nM
Compound 3 ended at the assay's limit (the forecaster's own chance of this, stated with the estimate: 55%); middle value at least 1.1-fold (0.05 log units) from the limit.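

Among the compounds shown here, compound 1 and compound 3 are each reported only as a limit in this assay, and no step between them can be read, because both sit at the same limit: the limit of > 25000 nM in this assay, at which 2 of the 3 values shown sit. The compounds shown leave open the true values of compound 1 and compound 3, and whether dimethylamino in place of nitro changes the amount of compound needed at all.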